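The compounds below may be only part of what the source reports. "The series", "measured", "known", "first", "only" and "open" are said of these compounds alone.

In a functional assay on cells (Lymphocyte, Homo sapiens), read by trypan blue exclusion, with a stated time of 16 h, tested at 0.1 uM (a higher number here means a stronger effect of the compound at the concentration tested, a lower number a weaker effect), compound 1 `Cc1c(N(C)C)nc(CCCCCCCCCCO)c(O)c1C` gives 17%. Compound 2 `CCCCCCCCCCCCCCCCc1nc(N(C)C)c(C)c(C)c1O` gives 80%, and compound 3 `CCCCCCCCCCCCCCCCCCCc1nc(N(C)C)c(C)c(C)c1O` gives 17%. Compound 2 stands highest of the three measured numbers: a number 63 percentage points higher from compound 1 to compound 2 (beyond the scatter) and a number 63 percentage points lower from compound 2 to compound 3 (beyond the scatter), whereas no change at the digits printed from compound 1 to compound 3 (within the scatter). All three measured steps concern the saturated chain, and none of them touches the amino group on the ring. Compound 4 `CCCCCCCCCCCCCCCCc1nc(N2CCC2)c(C)c(C)c1O` differs from compound 2 at exactly that untested place: azetidin-1-yl in place of dimethylamino on an aromatic carbon. The chain of compound 2 is kept unchanged in compound 4. Within the data shown here, no measured step bears on this change, so the measured compounds give no basis for predicting a shift in either direction. For compound 4 the expectation is that a number 10 percentage points lower from compound 2 to compound 4 (within the scatter) will remain within the scatter, though the wide spread among the three measured compounds leaves room for a larger move. For compound 4 the estimated value is 70%, with a range from 35% to 90%.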

Compound 4, a percentage reported as activity, at one concentration (the size of the read-out at that concentration, not a potency): 54%
The estimate for compound 4 lay 16 percentage points above the measured number; measured number inside the range.
By their numbers in this assay, from the lowest: compounds 1 and 3 (each within the scatter of the next); then compound 4; then compound 2.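

Among these compounds, the change from dimethylamino to azetidin-1-yl gives the first reading at this position, on an aromatic carbon next to the ring nitrogen, and in this assay it is a number 26 percentage points lower from compound 2 to compound 4 (beyond the scatter). The earlier steps shown here all lay on the saturated chain, so this shows that the read-out also responds to the group at this position, even with the chain of compound 2 kept unchanged. Nothing available explains why the read-out moves with this change.

From the compounds shown here alone, whether the drop follows from the four-membered ring itself or from the extra carbon stays open, and diethylamino, pyrrolidin-1-yl or morpholin-4-yl at this position would bear on that. Going by these compounds, it also remains open whether azetidin-1-yl would have the same effect on a shorter chain or a longer chain.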